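A few compounds are considered here, and "the series" means these few. Any claim that something is new, unique, unknown or untested is made for them only; others in the source may bear on it.

Of the compounds shown here, three built on one shared core have been tested in an ADME assay on HepG2 cells (Homo sapiens) for cytotoxicity, read by luminescence, CellTiter-Glo and ATP content, with a stated time of 72 h; on this read-out lower numbers stand for an effect already at smaller amounts and higher numbers for an effect only at larger amounts of compound. Compound 1 `COc1cccc(CNCCCNc2ccnc3cc(Oc4ccccc4)ccc23)c1O` gives 6800 nM, compound 2 `COc1cccc(CNCCCNc2ccnc3cc(C4CCCCC4)ccc23)c1O` gives 1080 nM, and compound 3 `COc1cccc(CNCCCNc2ccnc3cc(-c4ccc(F)cc4)ccc23)c1O` gives 6840 nM. Compound 3 has the highest number of the three, although a 1.0-fold higher number from compound 1 to compound 3 (0.00 log units; within the scatter) lies within the scatter, whereas a 6.3-fold higher number from compound 2 to compound 3 (0.80 log units; beyond the scatter) lies beyond it.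

Compound 4 `COc1cccc(CNCCCNc2ccnc3cc(-c4ccc(C(C)(C)C)cc4)ccc23)c1O` has not yet been measured. It differs from compound 3 by tert-butyl in place of fluoro on an aromatic carbon. Among the compounds with values here, no measured step repeats this exact change; the steps that bear on it are those at the same aromatic carbon of the core, namely a 6.3-fold lower number from compound 1 to compound 2 (0.80 log units; beyond the scatter) and a 6.3-fold higher number from compound 2 to compound 3 (0.80 log units; beyond the scatter), both modest and beyond the scatter, while a 1.0-fold higher number from compound 1 to compound 3 (0.00 log units; within the scatter) stayed within it. Compound 2, carrying a carbon-only ring at that carbon, gave the lowest number, and compound 4 likewise gains a carbon-only group, the tert-butyl, on the ring para to a large group. A step downward of modest size, a 2.3-fold lower number from compound 3 to compound 4 (0.36 log units; beyond the scatter), is therefore expected, though with considerable uncertainty since the pairs do not match. The estimate for compound 4 in this assay is 3000 nM, with a range from 1000 nM to 9000 nM.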

Compound 4, half-maximal effective concentration: 690 nM
For compound 4 the middle estimate is 4.3-fold (0.64 log units) above the measured one; measured number outside the range, below it.
By their numbers in this assay, from the lowest: compounds 4 and 2 (each within the scatter of the next); then compounds 1 and 3 (each within the scatter of the next).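

The exchange of 4-fluorophenyl for 4-(tert-butyl)phenyl shows that in this assay the number at this aromatic carbon does not depend only on the kind of group attached to the core, since a change on the outer ring alone gives a 9.9-fold lower number from compound 3 to compound 4 (1.00 log units; beyond the scatter). Compound 3 and compound 1 had left the aryl and phenoxy groups together at the higher numbers, with only the cyclohexyl of compound 2 lower, yet an aryl group now reaches that lower level: a 1.6-fold lower number from compound 2 to compound 4 (0.19 log units; within the scatter) stays within the scatter, whereas a 9.9-fold lower number from compound 1 to compound 4 (0.99 log units; beyond the scatter) lies beyond it. Nothing available here explains why tert-butyl and fluoro differ so much on this ring.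

With only fluoro and tert-butyl on the outer ring, the compounds shown leave open whether a methyl or an isopropyl group would give a step of intermediate size. They also leave open what a hydroxyl, an amine or a carboxylic acid in the same place would give in this assay.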